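Moving a chlorine on the benzyl group of a thioether

A few compounds are considered here, and "the series" means these few. Any claim that something is new, unique, unknown or untested is made for them only; others in the source may bear on it.

Three compounds have been measured in a functional assay on the whole organism (artery, strain albino) with Rattus norvegicus as the target, with a stated time of 900 min, at a dose of 10 mg/kg by the oral route; on this read-out higher numbers stand for more inhibition at the one dose given (going by the name of the read-out) and lower numbers for less inhibition:

Compound 1, `COc1ccc(C2N=C(SCc3ccccc3Cl)NC(C)=C2C(=O)Nc2ccc(F)cc2)cc1OC`, gives 21%.
Compound 2, `COc1ccc(C2N=C(SCc3cccc(Cl)c3)NC(C)=C2C(=O)Nc2ccc(F)cc2)cc1OC`, gives 13.3%.
Compound 3, `CC1=C(C(=O)Nc2ccc(Br)cc2)C(c2ccc(Cl)cc2Cl)N=C(SCc2ccccc2Cl)N1`, gives 16.4%.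

Compound 1 and compound 2 share a core and differ only in one group: 3-chlorophenyl in place of 2-chlorophenyl on a saturated chain carbon bound to a sulfur. This change gives a number 7.7 percentage points lower from compound 1 to compound 2 (within the scatter), a step that does not exceed the usual scatter of repeated measurements of this kind. Compound 3 carries a different core from compound 1, and the difference between the two cores is not broken down here. The values of compound 2 and compound 3 lie within the usual scatter of each other, so the two read as alike.

Compound 4, `CC1=C(C(=O)Nc2ccc(Br)cc2)C(c2ccc(Cl)cc2Cl)N=C(SCc2cccc(Cl)c2)N1`, has not yet been measured. It stands to compound 3 as compound 2 stands to compound 1: 3-chlorophenyl in place of 2-chlorophenyl on a saturated chain carbon bound to a sulfur. The place of the change is the same word for word in both pairs, so it is the same change made on a second core. For the measured compounds named here, its effect on the second core is not known, and only one example of the change has been measured. For compound 4 the step of a number 6.4 percentage points lower from compound 3 to compound 4 (within the scatter) is expected to be small, because a number 7.7 percentage points lower from compound 1 to compound 2 (within the scatter) stayed within the scatter, so a similar outcome is assumed. Compound 4 is therefore estimated to give 10%, with a range from 0% to 22% that allows for both the earlier step and the scatter of the read-out.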

Compound 4, a percentage reported as inhibition, in the whole organism at one dose (the size of the read-out at that dose, not a potency): 7.2%
Estimate against measurement, compound 4: 2.8 percentage points above; the range from low to high includes it.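

In this assay, putting 3-chlorophenyl in place of 2-chlorophenyl on the second core gives a number 9.2 percentage points lower from compound 3 to compound 4 (within the scatter), so this step, like the first, does not stand clear of the usual scatter of repeated measurements. Set side by side, the two steps read as the same size, and so far the change carries from one core to the other without any visible difference: the same change on two cores in this assay, a number 7.7 percentage points lower (within the scatter) from compound 1 to compound 2 and a number 9.2 percentage points lower (within the scatter) from compound 3 to compound 4, 1.5 percentage points apart, within the scatter of two such steps. This does not show that moving the chlorine has a real effect on the read-out, since neither step on its own exceeds the scatter, and two cores are too few to say how the change would behave on a third; the result also comes from one dose, so it says nothing about potency.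

The compounds shown leave open what would happen if the chlorophenyl on the chain carbon gave way to a different kind of group, such as a plain phenyl without chlorine or a carboxylic acid. They also leave open which of the several differences between the two cores matters for the read-out, as compound 1 and compound 3 differ in more than one place.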